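The source may report more compounds than this note shows. Statements on the series, on what has been measured and on what is new or still open speak of the compounds shown alone.

Compound 1, `COc1cc[nH]c1/C=C1\C(=O)Nc2ccc(F)c(C#C[C@H](N)CO)c21`, gives 320 nM in a functional assay on MDA-MB-435 cells (Homo sapiens) for inhibition; a lower number here means a stronger inhibitor, a higher number a weaker inhibitor.
Compound 2, `COc1cc[nH]c1/C=C1\C(=O)Nc2ccc(F)c(C#C[C@H](CO)NCCO)c21`, gives 1270 nM in this assay.
Compound 3, `COc1cc[nH]c1/C=C1\C(=O)Nc2ccc(F)c(C#CC3(O)CCOCC3)c21`, gives 600 nM in this assay.

Compound 3 sits between the other two: a 1.9-fold higher number from compound 1 to compound 3 (0.27 log units; within the scatter), whereas a 2.1-fold lower number from compound 2 to compound 3 (0.33 log units; beyond the scatter).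

Compound 4, `COc1cc[nH]c1/C=C1\C(=O)Nc2ccc(F)c(C#C[C@@H]3C[C@@H](O)CN3)c21`, differs from compound 3 by 4-hydroxypyrrolidin-2-yl in place of 4-hydroxyoxan-4-yl on a triple-bonded carbon. The entering group carries a ring nitrogen together with a hydroxyl, and so resembles the 1-amino-2-hydroxyethyl group of compound 1 more than the 4-hydroxyoxan-4-yl group of compound 3. Going by the values given here, two measured steps bear on this: a 1.9-fold higher number from compound 1 to compound 3 (0.27 log units; within the scatter), and a 4.0-fold higher number from compound 1 to compound 2 (0.60 log units; beyond the scatter). The first suggests little movement in this assay; the second only warns that a larger substituent on the nitrogen gave a modest loss, which compound 4 does not carry.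

Compound 4 is therefore expected to land close to compound 3 and compound 1, with an estimated 400 nM and a range of 150 nM to 1100 nM. The expected step of a 1.5-fold lower number from compound 3 to compound 4 (0.18 log units; within the scatter) stays within the scatter.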

Compound 4, half-maximal inhibitory concentration: 63 nM
The estimate for compound 4 lay 6.3-fold (0.80 log units) above the measured number; the whole stated range lies above it.
By their numbers in this assay, from the lowest: compound 4; then compounds 1 and 3 (each within the scatter of the next); then compound 2.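

In this assay, the earlier changes on this triple-bonded carbon gave either a higher number or one within the scatter, but 4-hydroxypyrrolidin-2-yl brings a clear gain, with a 5.1-fold lower number from compound 1 to compound 4 (0.71 log units; beyond the scatter). A ring alone does not account for this, as the comparison with the six-membered ring of 4-hydroxyoxan-4-yl gives a 9.5-fold lower number from compound 3 to compound 4 (0.98 log units; beyond the scatter). The widest gap, a 20-fold lower number from compound 2 to compound 4 (1.30 log units; beyond the scatter), shows how far this one group can move the number.

Nothing measured here explains these steps. A plain pyrrolidin-2-yl group, without the hydroxyl, would separate what the ring nitrogen contributes from what the hydroxyl contributes.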